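Ester to acid on a diaryl thiophene core

The compounds below may be only part of what the source reports. "The series", "measured", "known", "first", "only" and "open" are said of these compounds alone.

Measured so far:
Compound 1, `CCOC(=O)c1cc(-c2cc(OC)c(OC)c(OC)c2)c(-c2ccc(OC)c(OCc3ccccc3)c2)s1`: in a functional assay on SGC-7901 cells (Homo sapiens) for antiproliferative activity, read by MTT assay, with a stated time of 72 h (on this read-out higher numbers stand for weaker inhibition and lower numbers for stronger inhibition), compound 1 gives > 100000 nM, which is a limit of the assay.
Compound 2, `COc1ccc(-c2sc(C(=O)O)cc2-c2cc(OC)c(OC)c(OC)c2)cc1OCc1ccccc1`: in this assay compound 2 gives > 100000 nM, also a limit.
Going by the values given here, compound 3, `CCOC(=O)c1cc(-c2ccc(OC)cc2)c(-c2cc(OC)c(OC)c(OC)c2)s1`: in this assay compound 3 gives 6820 nM, the only number in the set.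

How the core of compound 1 differs from the core of compound 3 is not broken down here. From compound 1 to compound 2 the change is hydrogen in place of ethyl on an oxygen next to a carbonyl group. The step that the two limits leave unreadable from compound 1 to compound 2 cannot be read because the limit of > 100000 nM in this assay, at which 2 of the 3 values shown sit, holds both ends of it.

Compound 4, `COc1ccc(-c2cc(C(=O)O)sc2-c2cc(OC)c(OC)c(OC)c2)cc1`, awaits measurement. It stands to compound 3 as compound 2 stands to compound 1: the change is hydrogen in place of ethyl on an oxygen next to a carbonyl group, the same change at the same place. Among the compounds with values here, the only earlier example of it gives no readable size, so the expectation rests on compound 2, whose value > 100000 nM is a limit and leaves open that compound 4 may also return a limit rather than a number. The step of a 7.3-fold higher number from compound 3 to compound 4 (0.87 log units; beyond the scatter) is expected to be a loss. In this assay compound 4 is expected to give about 50000 nM, with a range from 7000 nM to 100000 nM.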

Compound 4, half-maximal inhibitory concentration: 4220 nM
The estimate for compound 4 lay 12-fold (1.07 log units) above the measured number, and the stated range ends above it.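

Ethoxycarbonyl to carboxy gives a 1.6-fold lower number from compound 3 to compound 4 (0.21 log units; within the scatter) in this assay, so on this core the ester and the acid are not separated by this read-out. The same change on the core of compound 1 cannot be read, since compound 1 and compound 2 both stand at a limit and the step has no size: the limit of > 100000 nM in this assay, at which 2 of the 4 values shown sit. The series therefore holds one readable example of this change, on one core; it does not show that the result carries over to the core of compound 1 or to any other core, and the unreadable pair neither supports nor contradicts it.

Open, on these data alone, is whether the change would give a readable step on a core whose ester and acid both return numbers rather than limits. Also open, as far as these compounds go, is how this place responds to a group other than ethoxycarbonyl or carboxy, such as a primary amide or a butyl ester, on the core of compound 3.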